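Biaryl pyrazole carboxylic acids: removing a chloro group

The compounds below may be only part of what the source reports. "The series", "measured", "known", "first", "only" and "open" are said of these compounds alone.

Measured so far:
- compound 1 `O=C(O)c1cc(-c2ccc(-c3ccc(Cl)cc3Cl)cc2)n(Cc2cccnc2)n1`: > 100000 nM
- compound 2 `O=C(O)c1cc(-c2ccc(-c3ccc(F)c(Cl)c3)cc2)n(-c2ccc(Cl)cc2Cl)n1`: 20900 nM
- compound 3 `O=C(O)c1cc(-c2ccc(-c3ccc(Cl)cc3Cl)cc2)nn1Cc1ccccn1`: 22300 nM

In an assay on isolated protein for inhibition of methionine--tRNA ligase, cytoplasmic (Homo sapiens) (on this read-out lower numbers stand for stronger inhibition and higher numbers for weaker inhibition), compound 2 gives 20900 nM, the lower of the two numeric values in hand. Compound 3 gives 22300 nM, which lies within the scatter of compound 2, so no order between the two can be read. The value of compound 1, > 100000 nM, is a limit of this assay and not a number; see (the limit of > 100000 nM in this assay, at which 1 of the 3 values shown sits). Compounds 1 and 3 differ from compound 2 in more than one place, so none of these pairs gives a clean step.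

Compound 4 `O=C(O)c1cc(-c2ccc(-c3ccc(F)cc3)cc2)n(-c2ccc(Cl)cc2Cl)n1` is not yet measured. It differs from compound 2 in one place: hydrogen in place of chloro on an aromatic carbon. Cut one bond further out, this reads 3-chloro-4-fluorophenyl to 4-fluorophenyl.

Among the compounds with values here, no measured step matches this change, so the expectation rests on the weak numbers seen across the series. A small loss, at most a modest step upward in this assay, or none beyond the scatter, is expected, giving a 1.7-fold higher number from compound 2 to compound 4 (0.22 log units; within the scatter). Compound 4 is therefore estimated at 35000 nM, within 10000 nM to 100000 nM.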

Compound 4, half-maximal inhibitory concentration: 41300 nM
Beside the measured number, compound 4's estimate is 1.2-fold (0.07 log units) below it; low and high end bracket the measured number.
By their numbers in this assay, from the lowest: compounds 2, 3 and 4 (each within the scatter of the next). At a limit, above all of these: compound 1.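

Replacing chloro with hydrogen on the aromatic carbon ortho to a fluoro group gives, in this assay, a 2.0-fold higher number from compound 2 to compound 4 (0.30 log units; within the scatter). Within the data shown here, this is the first step between compounds that differ in one place, and it gives a direct reading of this position rather than a comparison blurred by other differences. Within the scatter, the change from 3-chloro-4-fluorophenyl to 4-fluorophenyl gives no readable effect on inhibition, and no measurement in hand bears on the reason for this result.

The compounds shown carry only chloro or hydrogen on this carbon, so it remains open whether a methyl, a methoxy or an amine there would move the number beyond the scatter. As far as these compounds go, the fluoro group stays the same in both members of the pair, so it also remains open what a hydroxyl in its place would give, and whether the chloro-to-hydrogen step would read the same on the core of compound 3.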